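A few compounds are considered here, and "the series" means these few. Any claim that something is new, unique, unknown or untested is made for them only; others in the source may bear on it.

Two compounds of this series have a number in an ADME assay on microsomes from liver (Homo sapiens) for metabolic stability, tested at 2.5 uM (a higher number here means faster removal of the compound, a lower number slower removal), so far. Compound 1 `O=S(=O)(c1ccc(F)c(F)c1)c1cnc2c(F)cccc2c1-c1ccc(Cl)cc1` gives 0.28 mL/min, the lower of the two numbers. Among the compounds with values here, compound 2 `O=S(=O)(c1cc(Cl)cc(Cl)c1)c1cnc2cc(F)ccc2c1-c1ccccc1F` gives 0.93 mL/min in this assay, a higher number that lies beyond the scatter; the two structures differ in more than one place, so no single step is read from this pair. Compound 3 `O=S(=O)(c1ccc(F)c(Cl)c1)c1cnc2c(F)cccc2c1-c1ccc(Cl)cc1` has not yet been measured in this assay. It differs from compound 1 in one place: chloro in place of fluoro on an aromatic carbon. With no measured step of this kind in hand, the expected step is a 1.3-fold higher number from compound 1 to compound 3 (0.10 log units; within the scatter), within the scatter. Compound 3 is estimated at 0.35 mL/min, with a range from 0.15 mL/min to 0.8 mL/min.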

Compound 3, intrinsic clearance in a liver preparation (reported as CLH), per the amount of preparation that the assay uses: 0.01 mL/min
Estimate against measurement, compound 3: 35-fold (1.54 log units) above, and the stated range ends above it.
By their numbers in this assay, from the lowest: compound 3; then compound 1; then compound 2.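

In this assay, the change from 3,4-difluorophenyl to 3-chloro-4-fluorophenyl gives a 28-fold lower number from compound 1 to compound 3 (1.45 log units; beyond the scatter), a large step. A single halogen exchange on an aromatic carbon, ortho to a fluoro group, is thus enough to move this read-out far beyond the scatter, which the two-place difference between compound 1 and compound 2 could not show. Nothing measured on these compounds accounts for the size of this step.

Open, from the compounds shown here alone, is whether a bromo, methyl or methoxy group at this position would extend the step. Also open, going by these compounds, is whether the same exchange gives a step of this size with other groups elsewhere on the shared core.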